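Replacing a sulfonamide arm on the shared core

A few compounds are considered here, and "the series" means these few. Any claim that something is new, unique, unknown or untested is made for them only; others in the source may bear on it.

Measured so far:
- compound 1, `COc1cc(Br)c(S(=O)(=O)Nc2ccc(C(F)(F)F)c(O[C@@H]3CCN(C)C3)c2)cc1OC`: 34 nM
- compound 2, `CCN1CCN(c2cccc3c2CN([C@H](CCCNS(=O)(=O)c2c[nH]cn2)c2ccc(OC)c(OC)c2)C3=O)CC1`: 23 nM

Of the compounds shown here, two have been tested in a functional assay on CHO-K1 cells for antagonist activity at Urotensin-2 receptor (Rattus norvegicus), read by FLIPR and calcium flux, with a stated time of 1 h; on this read-out lower numbers stand for stronger inhibition and higher numbers for weaker inhibition. Compound 1 gives 34 nM. Compound 2 gives 23 nM, the lowest of the two numbers, but its nearest neighbour is compound 1 and that gap lies within the scatter of repeated measurements, so the two cannot be ranked against each other. Among the measured compounds shown here, no pair of compounds that differ in one place has been measured, so no step size is known from the data themselves.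

Compound 3, `CCN1CCN(c2cccc3c2CN([C@H](CCCNC(=O)c2cccs2)c2ccc(OC)c(OC)c2)C3=O)CC1`, has not yet been measured. It differs from compound 2 in one place: (thiophen-2-yl)carbonyl in place of (1H-imidazol-4-yl)sulfonyl on an amine nitrogen. For the measured compounds named here, with no measured step to lean on, the expectation rests on the size of the change alone. The leaving group and the entering group are of similar size, but a hydrogen-bond donor is lost and one acceptor fewer remains. A modest weakening is expected, with a fair chance of no step beyond the scatter: the step from compound 2 to compound 3 is estimated at a 2.6-fold higher number from compound 2 to compound 3 (0.42 log units; beyond the scatter). Compound 3 is therefore expected to give about 60 nM in this assay, in a range from 15 nM to 250 nM.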

Compound 3, half-maximal inhibitory concentration: 7 nM
Estimate against measurement, compound 3: 8.6-fold (0.93 log units) above; the measured number lies below the stated range.
By their numbers in this assay, from the lowest: compound 3; then compounds 2 and 1 (each within the scatter of the next).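

In this assay, among the compounds shown here, (thiophen-2-yl)carbonyl in place of (1H-imidazol-4-yl)sulfonyl on the amine nitrogen gives a 3.3-fold lower number from compound 2 to compound 3 (0.52 log units; beyond the scatter), the first step on this core that lies beyond the scatter, and it shows that the number responds to the group carried at this position. The (1H-imidazol-4-yl)sulfonyl group is not needed to reach low nanomolar numbers here: the group that replaces it has 0 hydrogen-bond donors and 2 hydrogen-bond acceptors against 1 and 3, and the number still falls. Nothing measured on hand bears on why this exchange lowers the number.

The ring and the linking group change at once in this step, so the compounds shown leave open which of the two carries it; (thiophen-2-yl)sulfonyl and (1H-imidazol-4-yl)carbonyl on the same amine nitrogen would separate them. Also open, on these data alone, is how far the trend extends, for instance whether a benzoyl group in this place, or a longer chain leading to the amine nitrogen, would lower the number further in this assay or raise it again.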